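Cyclopentyl in place of methyl: a larger ketone substituent

The source may report more compounds than this note shows. Statements on the series, on what has been measured and on what is new or still open speak of the compounds shown alone.

Measured so far:
Compound 1, `Cc1c(OCCCCOCOc2ccc(C(=O)O)cc2)ccc(C(=O)CC2CCCC2)c1O`, gives 46.9%.
Compound 2, `Cc1c(OCCCCOc2ccc(F)c(C(=O)O)c2)ccc(C(=O)CC(C)(C)C)c1O`, gives 102%.
Compound 3, `CCC(=O)c1ccc(OCCCCOc2ccc(F)c(C(=O)O)c2)c(C)c1O`, gives 18.4%.

All three were run in an assay on HEK293 cells for positive allosteric modulation of metabotropic glutamate receptor 3 (Rattus norvegicus), read by thallium flux, with a stated time of 2.5 min; on this read-out lower numbers stand for smaller maximal responses and higher numbers for larger maximal responses. Compound 3 stands lowest of the three numbers; its nearest neighbour is compound 1, and the furthest is compound 2. For the measured compounds named here, the step from compound 2 to compound 3 is the one measured change at this place, and it was large: a number 83.6 percentage points lower from compound 2 to compound 3 (beyond the scatter).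

Compound 4, `Cc1c(OCCCCOc2ccc(F)c(C(=O)O)c2)ccc(C(=O)CC2CCCC2)c1O`, is not yet measured. It differs from compound 3 in one place: cyclopentyl in place of methyl on a saturated chain carbon bound to a carbonyl carbon.

The step from compound 2 to compound 3 shows that a smaller group on the saturated chain carbon bound to the carbonyl carbon went with a much smaller maximal response. Going the other way, from methyl to cyclopentyl, the expected direction in this assay is therefore upward. Compound 1, which carries cyclopentyl with a different linker, also sits above compound 3. The expected step is a number 61.6 percentage points higher from compound 3 to compound 4 (beyond the scatter), and compound 4 is estimated at 80%, within a range from 45% to 110%.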

Compound 4, largest response reached (reported as percent of maximum), in percent of the reference or control that the assay uses: 98.4%
Compound 4: the middle estimate sits 18.4 percentage points below what was measured; low and high end bracket the measured number.
By their numbers in this assay, from the lowest: compound 3; then compound 1; then compounds 4 and 2 (each within the scatter of the next).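

In this assay the change gives a number 80 percentage points higher from compound 3 to compound 4 (beyond the scatter) and lifts the response well away from where methyl left it, while cyclopentyl in place of tert-butyl gives a number 3.6 percentage points lower from compound 2 to compound 4 (within the scatter) and leaves these two larger groups level. Two carbon groups of different shape, one a ring and one branched, thus read alike on the saturated chain carbon bound to a carbonyl carbon, and of the three groups only methyl stands apart. With cyclopentyl held fixed, a second place counts too: 3-carboxy-4-fluorophenyl in place of (4-carboxyphenoxy)methyl on an oxygen on a saturated carbon gives a number 51.5 percentage points higher from compound 1 to compound 4 (beyond the scatter) and shows that this group alone does not settle the response.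

The compounds shown leave open where between methyl and the larger groups the response climbs, as with ethyl or isopropyl, and how a ring carrying an oxygen, such as tetrahydropyranyl, would read. They also offer no measured reason for any of these steps.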